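Benzyl in place of isopropyl: cytotoxicity notes on compound 3

The source may hold more compounds than are shown below. What is called first, only, known or untested is meant among the compounds shown, and "the series" means these compounds.

Measured in an ADME assay on CEM-SS cells (Homo sapiens) for cytotoxicity, read by XTT assay, with a stated time of 6 days; on this read-out lower numbers stand for higher toxicity in this test and higher numbers for lower toxicity in this test:
compound 1 `CCCC(=O)OCSc1ccccc1C(=O)NCC(=O)NC`: > 100 uM
compound 2 `CCCC(=O)OCSc1ccccc1C(=O)NCC(=O)NC(C)C`: 92 uM

Compound 1 gives > 100 uM as its entry, and this is a limit of the assay and not a number. Within the data shown here, compound 2, with 92 uM, holds the only true number so far. Its standing can be read only against the entry of compound 1. The next compound is compound 3 `CCCC(=O)OCSc1ccccc1C(=O)NCC(=O)NCc1ccccc1`, with benzyl in place of isopropyl on an amide-type nitrogen. Among the measured compounds shown here, one measured step bears on this change, made on the same kind of nitrogen: isopropyl in place of methyl gave an at least 1.0-fold lower number from compound 1 to compound 2 (0.03 log units; that floor lies within the scatter), and that step is bounded by the limit of > 100 uM in this assay, at which 1 of the 2 values shown sits, and gives no firm size. Going by that step alone, only a small move toward lower numbers in this assay is expected, not clearly beyond the scatter. The expected step is a 1.5-fold lower number from compound 2 to compound 3 (0.19 log units; within the scatter) and it rests on very little. Compound 3 is estimated at 60 uM, with an expected range from 25 uM to 120 uM (the range is an estimate).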

Compound 3, half-maximal toxic concentration: 29.3 uM
Compound 3: middle estimate off by 2.0-fold (0.31 log units), on the high side; the range from low to high includes it.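

In this assay, the amide-type nitrogen now shows a move beyond the scatter: benzyl, which brings a six-membered aromatic ring of carbon only, in place of isopropyl gives a 3.1-fold lower number from compound 2 to compound 3 (0.50 log units; beyond the scatter), a shift toward higher toxicity in this test that the earlier step on this nitrogen could not show at any firm size. Compound 1 gives > 100 uM, which is a limit and not a number. Read against that limit, phenyl in place of hydrogen on a saturated chain carbon bound to an amide-type nitrogen gives an at least 3.4-fold lower number from compound 1 to compound 3 (0.53 log units; beyond the scatter), so this step has a floor and no firm upper size: the limit of > 100 uM in this assay, at which 1 of the 3 values shown sits.

Going by these compounds, whether the move goes with the aromatic ring or only with the larger carbon count stays open, and a cyclohexylmethyl group or a longer chain such as hexyl on this nitrogen would separate the two. Also open, on these data alone, is how far the read-out would follow a phenyl set directly on the nitrogen, a phenethyl group, or a benzyl carrying a carboxylic acid or an amine.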